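The source may hold more compounds than are shown below. What is called first, only, known or untested is meant among the compounds shown, and "the series" means these compounds.

Measured compounds:
compound 1 `Cc1c(C(=O)N/N=C\c2cccc(O)c2O)oc2cccc(O)c12`: in a functional assay on PC-3 cells (Homo sapiens) for inhibition (on this read-out lower numbers stand for stronger inhibition and higher numbers for weaker inhibition), compound 1 gives 12200 nM
compound 2 `Cc1c(C(=O)N/N=C\c2cccc(O)c2)oc2cccc(O)c12`: in this assay compound 2 gives 17600 nM

Compound 2 stands highest of the two numbers in this assay; its nearest neighbour is compound 1, and the step of a 1.4-fold higher number from compound 1 to compound 2 (0.16 log units; within the scatter) stays within the scatter, so the two cannot be ranked.

Compound 3 `Cc1c(C(=O)N/N=C\c2ccncc2)oc2cccc(O)c12` is not yet measured. The change from compound 2 is pyridin-4-yl in place of 3-hydroxyphenyl on a carbon with a double bond to nitrogen. Within the data shown here, only one measured step bears on it: a 1.4-fold higher number from compound 1 to compound 2 (0.16 log units; within the scatter) removed a hydroxy on an aromatic carbon and moved the number within the scatter. Among the measured compounds shown here, the change to compound 3 again removes the hydroxy, but it also replaces the carbon-only ring by pyridin-4-yl, and no measured pair covers that ring exchange. For the measured compounds named here, with the one relevant step small, the expectation for this assay is no step beyond the scatter, with a slight lean towards a higher number. The step expected, a 1.3-fold higher number from compound 2 to compound 3 (0.10 log units; within the scatter), is small. Compound 3 is estimated at 22000 nM, with a range from 8000 nM to 60000 nM.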

Compound 3, half-maximal inhibitory concentration: >= 40000 nM
Compound 3: a limit, no number (the forecaster's own chance of this, stated with the estimate: 15%); middle value at least 1.8-fold (0.25 log units) away from the limit.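

On the carbon with a double bond to nitrogen, the series now shows a change that moves the number beyond the scatter in this assay, with pyridin-4-yl in place of 3-hydroxyphenyl giving an at least 2.2-fold higher number from compound 2 to compound 3 (0.35 log units; beyond the scatter). Compound 3 has a limit and not a number, so this step gives only a minimum size: the limit of >= 40000 nM in this assay, at which 1 of the 3 values shown sits. Replacing the 2,3-dihydroxyphenyl group gives an at least 3.2-fold higher number from compound 1 to compound 3 (0.51 log units; beyond the scatter), whereas removing one hydroxy while keeping the carbon-only ring gave a 1.4-fold higher number from compound 1 to compound 2 (0.16 log units; within the scatter), so inhibition at this place in the series holds through that single removal but weakens with the full exchange to pyridin-4-yl.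

The exchange to pyridin-4-yl both removes the remaining hydroxy and puts a nitrogen into the ring, and the compounds shown do not separate these two changes. A plain phenyl group on the same carbon would bear directly on that question, and a pyridin-3-yl group or an aminophenyl group would show whether the loss of inhibition depends on the kind and place of the nitrogen.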